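Swapping Phenyl for Cyclohexylethyl in a Receptor Agonist Series

The source may hold more compounds than are shown below. What is called first, only, known or untested is meant among the compounds shown, and "the series" means these compounds.

The measured compounds and their numbers:
Compound 1, `CCCCCNC(=O)/N=C(\N)NCCCc1sc(N)nc1C`, gives 178 nM.
Compound 2, `Cc1nc(N)sc1CCCN/C(N)=N/C(=O)NCC(C)CCc1ccccc1`, gives 355 nM.
Compound 3, `Cc1nc(N)sc1CCCN/C(N)=N/C(=O)NCc1ccccc1`, gives 100 nM.

All three were tested in a functional assay on HEK293T cells for agonist activity at histamine H2 receptor (Homo sapiens), read by beta-arrestin recruitment; on this read-out lower numbers stand for an effect already at smaller amounts and higher numbers for an effect only at larger amounts of compound. Compound 3 has the lowest number of the three. Its nearest neighbour is compound 1, and that gap is within the scatter, so the two cannot be told apart. The gap to compound 2 is beyond the scatter, so compound 2 clearly needs more material.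

Compound 4, `Cc1nc(N)sc1CCCN/C(N)=N/C(=O)NCC(C)C1CCCCC1`, has not been measured. It differs from compound 3 in one place: 1-cyclohexylethyl in place of phenyl on a saturated chain carbon bound to an amide-type nitrogen.

Among the measured compounds shown here, only one measured step touches this position. It is a 1.8-fold lower number from compound 1 to compound 3 (0.25 log units; within the scatter), where a saturated chain and a phenyl gave numbers that did not differ beyond the scatter. Compound 2, carrying a longer branched chain with a phenyl at its end, gives a higher number than compound 3. For the measured compounds named here, a branched saturated group like the one entering in compound 4 therefore is expected to sit somewhat higher than compound 3, but with no step known for a ring of this kind the expectation is loose.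

The step from compound 3 to compound 4 is estimated as a 3.0-fold higher number from compound 3 to compound 4 (0.48 log units; beyond the scatter). Compound 4 is expected to give 300 nM, in a range from 100 nM to 900 nM.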

Compound 4, half-maximal effective concentration: 224 nM
The estimate for compound 4 lay 1.3-fold (0.13 log units) above the measured number, within the range that was stated.
By their numbers in this assay, from the lowest: compounds 3, 1, 4 and 2 (each within the scatter of the next, the first and the last beyond it).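

In this assay, this position on a saturated chain carbon bound to an amide-type nitrogen responds to exchanging an aromatic ring for a non-aromatic one: 1-cyclohexylethyl in place of phenyl gives a 2.2-fold higher number from compound 3 to compound 4 (0.35 log units; beyond the scatter), a modest step, whereas the earlier step from butyl to phenyl stayed within the scatter. The new group does not set compound 4 apart from the other two compounds, since 1-cyclohexylethyl in place of butyl gives a 1.3-fold higher number from compound 1 to compound 4 (0.10 log units; within the scatter), and cyclohexyl in place of phenethyl gives a 1.6-fold lower number from compound 2 to compound 4 (0.20 log units; within the scatter). The type of ring alone therefore does not order these compounds: compound 1, with its open butyl chain and no ring at this position, cannot be told apart from either compound 3 or compound 4.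

From the compounds shown here alone, it remains open whether a smaller cyclohexylmethyl group, or a cyclohexyl ring carrying an amine or a carboxylic acid, would give a number closer to that of compound 3 or compound 4. Nothing available here gives a measured reason for the step from phenyl to 1-cyclohexylethyl.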